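This account rests on a few compounds, and the source may have more. Where it says the series, first, only, none or still open, it means among the compounds named here.

Values in a functional assay on K562 cells (Homo sapiens) for antiproliferative activity, read by MTT assay, with a stated time of 72 h; on this read-out lower numbers stand for stronger inhibition and higher numbers for weaker inhibition:
- compound 1 `COc1cc(C(=O)c2sc3ccccc3c2-c2ccccc2)cc(OC)c1OC`: 2100 nM
- compound 2 `COc1cc(C(=O)c2sc3ccccc3c2-c2ccc(C)cc2)cc(OC)c1OC`: 3500 nM
- compound 3 `COc1ccc(-c2c(C(=O)c3cc(OC)c(OC)c(OC)c3)sc3ccccc23)c(OC)c1`: 4100 nM

Compound 3, at 4100 nM, is not separated from the other two compounds: the measured steps are a 2.0-fold higher number from compound 1 to compound 3 (0.29 log units; within the scatter) and a 1.2-fold higher number from compound 2 to compound 3 (0.07 log units; within the scatter). The next compound is compound 4 `COc1cc(C(=O)c2sc3ccccc3c2Nc2ccccc2)cc(OC)c1OC`, not yet measured. Its change from compound 3 is anilino in place of 2,4-dimethoxyphenyl on an aromatic carbon.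

The closest evidence comes from changes to the ring at this same place. Alongside the two steps above, there is a 1.7-fold higher number from compound 1 to compound 2 (0.22 log units; within the scatter). All three stay within the scatter, so this place has so far tolerated the changes tried. For the measured compounds named here, none of them, however, introduces anilino, so the data offer no direct precedent and the range has to stay wide. No step beyond the scatter is expected in this assay. The expected step is a 1.4-fold lower number from compound 3 to compound 4 (0.14 log units; within the scatter). The estimate for compound 4 is 3000 nM, with an expected range of 800 nM to 10000 nM.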

Compound 4, half-maximal inhibitory concentration: 2300 nM
Beside the measured number, compound 4's estimate is 1.3-fold (0.12 log units) above it; the measured number falls inside the stated range.
By their numbers in this assay, from the lowest: compounds 1, 4, 2 and 3 (each within the scatter of the next).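

In this assay, for the compounds shown here, anilino is the only group tried at this place with a hydrogen-bond donor and a nitrogen attached to the ring, and it stays within the scatter of all three aryl compounds (a 1.1-fold higher number from compound 1 to compound 4 (0.04 log units; within the scatter); a 1.5-fold lower number from compound 2 to compound 4 (0.18 log units; within the scatter); a 1.8-fold lower number from compound 3 to compound 4 (0.25 log units; within the scatter)). The tolerance seen so far among directly attached aryl groups therefore extends to this change, despite the different atom attached to the ring and the different hydrogen-bond counts. Nothing available explains this tolerance.

As far as these compounds go, whether the amine hydrogen matters remains open, and N-methylanilino would be the direct comparison. Also open, from the compounds shown here alone, is whether the tolerance extends to groups without an aromatic ring, such as a primary amine, a carboxylic acid or a longer alkyl chain.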